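Selenocyanate Carbamates: Exchanging Methoxy for Chloro

The source may hold more compounds than are shown below. What is called first, only, known or untested is meant among the compounds shown, and "the series" means these compounds.

Of the compounds shown here, two with a shared core have been tested for their ability to stop the growth of a leukaemia cell line. Compound 1 `COc1ccc(OC(=O)Nc2ccc([Se]C#N)cc2)cc1` carries a methoxy group on its outer ring; in a functional assay on CCRF-CEM cells (Homo sapiens) for cytotoxicity, read by MTT assay, with a stated time of 72 h (a higher number here means a weaker inhibitor of growth, a lower number a stronger inhibitor of growth), compound 1 gives 13000 nM. Compound 2 `C=CCOC(=O)Nc1ccc([Se]C#N)cc1` carries an allyl carbamate instead, and in this assay compound 2 gives 9200 nM. Compound 1 has the higher of the two numbers, but its gap to compound 2 lies within the scatter of repeated measurements, so the two cannot be told apart. Compound 3 `N#C[Se]c1ccc(NC(=O)Oc2ccc(Cl)cc2)cc1` differs from compound 1 in one place: chloro in place of methoxy on an aromatic carbon. Going by the values given here, no measured pair shows what this exchange does, and the two numbers in hand lie close together, so no step beyond the scatter is expected in this assay in either direction. Compound 3 is expected to give about 11000 nM in this assay, with a likely range from 4500 nM to 28000 nM, which amounts to an expected step of a 1.2-fold lower number from compound 1 to compound 3 (0.07 log units; within the scatter).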

Compound 3, concentration for 50% growth inhibition: 18300 nM
Compound 3: middle estimate off by 1.7-fold (0.22 log units), on the low side; measured number inside the range.
By their numbers in this assay, from the lowest: compounds 2, 1 and 3 (each within the scatter of the next).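

Going by these compounds alone, this is the first direct reading of the aromatic carbon para to a large group: in this assay, chloro in place of methoxy gives a 1.4-fold higher number from compound 1 to compound 3 (0.15 log units; within the scatter). So the two compounds cannot be told apart in this assay, and swapping methoxy for chloro at this position produces no step beyond the scatter. No supporting measurement bears on this result.

The compounds shown leave open whether any other group at this position, such as an amine or a carboxylic acid, would move the number beyond the scatter. All three numbers also lie within the scatter of their neighbours in the ranking, so it remains unclear which parts of these molecules, if any, govern growth inhibition in this assay and which can be changed freely.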